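The source may hold more compounds than are shown below. What is called first, only, known or untested is meant among the compounds shown, and "the series" means these compounds.

Measured compounds:
compound 1, `CCNc1[nH]c(=O)n(O)c(=O)c1C(=O)NCc1ccccc1`: 355 uL/min
compound 2, `CCNc1[nH]c(=O)n(O)c(=O)c1C(=O)NCc1ccc(F)cc1`: 336 uL/min

Both numbers come from an ADME assay on microsomes from liver (Mus musculus) for metabolic stability; on this read-out lower numbers stand for slow clearance and higher numbers for fast clearance. In this assay compound 1 gives 355 uL/min and compound 2 gives 336 uL/min; the two are separated only by a 1.1-fold lower number from compound 1 to compound 2 (0.02 log units; within the scatter), so compound 1 stands at one end of a pair whose two numbers cannot be told apart.

Compound 3, `CCNc1[nH]c(=O)n(O)c(=O)c1C(=O)NCc1ccc(C)c(F)c1`, has not yet been measured in this assay. It differs from compound 1 by 3-fluoro-4-methylphenyl in place of phenyl on a saturated chain carbon bound to an amide-type nitrogen. Among the measured compounds shown here, of the measured steps, only a 1.1-fold lower number from compound 1 to compound 2 (0.02 log units; within the scatter) bears on this change, and it covers just the fluoro part of it: the methyl part of the 3-fluoro-4-methylphenyl group has no measured counterpart. For the measured compounds named here, with the one relevant step lying within the scatter, and nothing to show how the methyl part behaves, no step beyond the scatter is expected from compound 1 to compound 3.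

The expected step is a 1.0-fold higher number from compound 1 to compound 3 (0.02 log units; within the scatter), and the corresponding estimate for compound 3 in this assay is 370 uL/min, with a range from 200 uL/min to 680 uL/min.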

Compound 3, intrinsic clearance in a liver preparation (reported as CLH), per the amount of preparation that the assay uses: 357 uL/min
For compound 3 the middle estimate is 1.0-fold (0.02 log units) above the measured one; the range from low to high includes it.
By their numbers in this assay, from the lowest: compounds 2, 1 and 3 (each within the scatter of the next).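

In this assay, among the compounds shown here, the step of a 1.0-fold higher number from compound 1 to compound 3 (0.00 log units; within the scatter) is the first reading on a change that goes beyond fluoro: the 3-fluoro-4-methylphenyl group, with its added methyl, enters on a saturated chain carbon bound to an amide-type nitrogen and leaves the number indistinguishable from that of phenyl. The comparison with the 4-fluorophenyl group gives the same picture, with a 1.1-fold higher number from compound 2 to compound 3 (0.03 log units; within the scatter), so phenyl, 4-fluorophenyl and 3-fluoro-4-methylphenyl cannot be told apart at this position in this assay. No available evidence accounts for this flat read-out.

Open, as far as these compounds go, is whether a group of a different kind on the ring, such as an amine or a carboxylic acid, or a longer chain in place of the single saturated chain carbon, would move the number beyond the scatter. All three compounds share the same core and differ only in this aryl group, so the compounds shown say nothing about how changes elsewhere on the core would read in this assay.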